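Ethyl and carboxy variants of a quinoline carboxamide series

The source may report more compounds than this note shows. Statements on the series, on what has been measured and on what is new or still open speak of the compounds shown alone.

Compound 1 `Cc1ccc2nc(C(=O)Nc3c(F)cc(-c4cccc(F)c4)cc3F)c(C)c(O)c2c1` gives 19.2% in a functional assay on Hep 3B2 cells (Homo sapiens) for antiproliferative activity, read by MTT assay, with a stated time of 24 h, tested at 3.7 ug/mL; on this read-out lower numbers stand for a weaker effect and higher numbers for a stronger effect at the one concentration tested. Compound 2 `CCc1ccc2nc(C(=O)Nc3c(F)cc(-c4cccc(F)c4)cc3F)c(C)c(O)c2c1`, differing by methyl in place of hydrogen on a saturated chain carbon bound to an aromatic carbon, gives 31.2%; the step is a number 12 percentage points higher from compound 1 to compound 2 (beyond the scatter). Compound 3 `Cc1ccc2nc(C(=O)Nc3c(F)cc(-c4cccc(F)c4)cc3F)c(C)c(C(=O)O)c2c1` differs from compound 1 by carboxy in place of hydroxy on an aromatic carbon. In this assay compound 3 gives 31.3%, and the step is a number 12.1 percentage points higher from compound 1 to compound 3 (beyond the scatter). Compound 2 and compound 3 lie within the scatter of each other.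

Compound 4 `CCc1ccc2nc(C(=O)Nc3c(F)cc(-c4cccc(F)c4)cc3F)c(C)c(C(=O)O)c2c1` is not yet measured. It differs from compound 3 by methyl in place of hydrogen on a saturated chain carbon bound to an aromatic carbon, the same change as from compound 1 to compound 2, at the same place. The two cores differ by carboxy in place of hydroxy on an aromatic carbon.

For the measured compounds named here, the step of a number 9.7 percentage points higher from compound 3 to compound 4 (within the scatter) is expected to resemble the earlier one, because a number 12 percentage points higher from compound 1 to compound 2 (beyond the scatter) is the only precedent for this change. Going by the values given here, with only one precedent, and one on a different core, the range is kept wide. For compound 4 the expected read-out is 41%, between 28% and 56%.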

Compound 4, a percentage reported as inhibition, at one concentration (the size of the read-out at that concentration, not a potency): 15.2%
Compound 4: the middle estimate sits 25.8 percentage points above what was measured, outside the stated range (below it).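

In this assay, methyl in place of hydrogen on the saturated chain carbon gives a number 16.1 percentage points lower from compound 3 to compound 4 (beyond the scatter), so the change does not carry from the core of compound 1 to the core of compound 3: the same change on two cores in this assay, a number 12 percentage points higher (beyond the scatter) from compound 1 to compound 2 and a number 16.1 percentage points lower (beyond the scatter) from compound 3 to compound 4, 28.1 percentage points apart, beyond the scatter of two such steps. Read the other way, carboxy in place of hydroxy gives a number 16 percentage points lower from compound 2 to compound 4 (beyond the scatter), so that change also depends on the group present elsewhere: the same change on two cores in this assay, a number 12.1 percentage points higher (beyond the scatter) from compound 1 to compound 3 and a number 16 percentage points lower (beyond the scatter) from compound 2 to compound 4, 28.1 percentage points apart, beyond the scatter of two such steps. The two changes therefore do not add in these four compounds, but a single pair of cores at one concentration does not show why, or whether this holds beyond them.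

Still open, as far as these compounds go, is how a longer chain such as propyl would behave on either core. Also open, from the compounds shown here alone, is whether an amine or a methoxy in place of the carboxy would follow the same course.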